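The source may hold more compounds than are shown below. What is called first, only, known or untested is meant among the compounds shown, and "the series" means these compounds.

Measured in a physicochemical assay for lipophilicity; on this read-out lower numbers stand for lower lipophilicity and higher numbers for higher lipophilicity:
- compound 1 `CCCCCCN(CCCCCSc1nc2ccccc2s1)C(=O)Nc1ccc(F)cc1F`: 7.78
- compound 2 `CCCCCCN(CCCCCSc1nc2cc(C)ccc2[nH]1)C(=O)Nc1ccc(F)cc1F`: 7.79
- compound 3 `CCCCCCN(CCCCCSc1nc2ccc[nH]c-2n1)C(=O)Nc1ccc(F)cc1F`: 6.22

Of these three, compound 3 stands lowest, with 6.22, and the other two sit well clear of it. Next in the series is compound 4 `CCCCCCN(CCCCCSc1nc2c[nH]cnc-2n1)C(=O)Nc1ccc(F)cc1F`, which keeps the rest of compound 3 and alters only the group on the sulfur: a group of 9 heavy atoms (5 carbon, 4 nitrogen; one five-membered aromatic ring with 2 hetero atoms, one six-membered aromatic ring with 2 hetero atoms) in place of a group of 9 heavy atoms (6 carbon, 3 nitrogen; one five-membered aromatic ring with 2 hetero atoms, one six-membered aromatic ring with 1 hetero atom), on a sulfur.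

Going by the values given here, three measured steps bear on this change. Exchanging one group with a six-membered aromatic ring of carbon only for another gave a number 0.01 log units higher from compound 1 to compound 2 (within the scatter). Moving to a six-membered aromatic ring with 1 hetero atom gave a number 1.56 log units lower from compound 1 to compound 3 (beyond the scatter) and a number 1.57 log units lower from compound 2 to compound 3 (beyond the scatter). All three compounds fit one reading, with none against it: the value drops when hetero atoms enter the six-membered ring. However, three compounds are thin support, and no measured step goes from 1 hetero atom to 2 in that ring. The two large steps also exchanged more of the group than the present change does, so only part of their size is carried over.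

The direction expected in this assay is downward, and the estimate is a number 0.72 log units lower from compound 3 to compound 4 (beyond the scatter). For compound 4 the expected value is 5.5, with an estimated range from 4.9 to 6.1.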

Compound 4, partition coefficient: 5.26
Beside the measured number, compound 4's estimate is 0.24 log units above it; low and high end bracket the measured number.
By their numbers in this assay, from the lowest: compound 4; then compound 3; then compounds 1 and 2 (each within the scatter of the next).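

In this assay, the move from 1 hetero atom to 2 in the six-membered aromatic ring gives a number 0.96 log units lower from compound 3 to compound 4 (beyond the scatter) on a sulfur whose other neighbours are: saturated chain carbon, so the fall seen earlier extends to a further exchange in that ring with the size of the group unchanged at 9 heavy atoms. Going by these compounds alone, measured against the groups with a six-membered aromatic ring of carbon only, the change now amounts to a number 2.53 log units lower from compound 2 to compound 4 (beyond the scatter) and a number 2.52 log units lower from compound 1 to compound 4 (beyond the scatter), and across the four compounds the value falls as hetero atoms in that ring increase, with no compound against this order. No measured data on these compounds explain the fall.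

Compounds 3 and 4 do not separate the number of ring nitrogens from where they sit, so a group with the same atoms arranged differently could land elsewhere on this read-out. As far as these compounds go, whether an amine or a carboxylic acid added to the group on the sulfur, or a shorter chain in the shared core, would shift this assay further or leave it unchanged also stays open.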